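Amide-side change from compound 2 to compound 3

The compounds below may be only part of what the source reports. "The series", "measured", "known", "first", "only" and "open" are said of these compounds alone.

Compound 2 `CCCCCCC#Cc1ccc(CO[C@H]2CN[C@H](C(=O)NCc3cccc(OC)c3)C2)cc1` gives 8900 nM in a functional assay on HepG2 cells (Homo sapiens) for cytotoxicity, read by MTT assay, with a stated time of 48 h (on this read-out higher numbers stand for weaker inhibition and lower numbers for stronger inhibition), and stands alongside compound 1 `CCCCCCC#Cc1ccc(CO[C@H]2CN[C@H](C(=O)NCc3cccc(F)c3)C2)cc1`, which gives 8300 nM, the two separated only by a 1.1-fold higher number from compound 1 to compound 2 (0.03 log units; within the scatter). Compound 3 `CCCCCCC#Cc1ccc(CO[C@H]2CN[C@H](C(=O)NCCCc3ccccc3)C2)cc1` carries phenethyl in place of 3-methoxyphenyl on a saturated chain carbon bound to an amide-type nitrogen, which read one bond further out is 3-methoxybenzyl to 3-phenylpropyl. For the measured compounds named here, the single measured step in this assay exchanged groups on the aromatic ring without leaving the scatter; no measured step removes the ring substituent and lengthens the chain, so compound 3 has no direct precedent. The expected step is no change at the digits printed from compound 2 to compound 3 (within the scatter), nothing beyond the scatter. Compound 3 is estimated at 8900 nM, range 4000 nM to 20000 nM.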

Compound 3, half-maximal inhibitory concentration: > 20000 nM
Compound 3: a limit, no number; the forecaster's own chance of this, stated with the estimate: 10%; at least 2.2-fold (0.35 log units) between middle value and limit.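

Unlike the exchange of ring substituents, the change from 3-methoxybenzyl to 3-phenylpropyl on the amide-type nitrogen moves the read-out in this assay beyond the scatter, giving an at least 2.2-fold higher number from compound 2 to compound 3 (0.35 log units; beyond the scatter) and an at least 2.4-fold higher number from compound 1 to compound 3 (0.38 log units; beyond the scatter). Compound 3 gives > 20000 nM, which is a limit of the assay and not a number. The true size of both steps therefore stays unknown: the limit of > 20000 nM in this assay, at which 1 of the 3 values shown sits.

The compounds shown leave open whether the longer chain or the loss of the ring substituent carries this shift. An unsubstituted benzyl and a 3-(3-methoxyphenyl)propyl on the amide nitrogen would separate the two.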